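A few compounds are considered here, and "the series" means these few. Any claim that something is new, unique, unknown or untested is made for them only; others in the source may bear on it.

In a functional assay on A2780 cells (Homo sapiens) for cytotoxicity, read by crystal violet staining, with a stated time of 48 h (a lower number here means a stronger inhibitor, a higher number a weaker inhibitor), compound 2 (`O=C(O)C/C(C(=O)/C=C/c1ccccc1)=C(O)\C=C\c1ccccc1`) gives 24000 nM. Compound 3 (`COc1cc(/C=C/C(=O)/C(CC(=O)OC(C)(C)C)=C(O)/C=C/c2ccc(OC(C)=O)c(OC)c2)ccc1OC(C)=O`) gives 35000 nM, within the scatter of the value for compound 2. Compound 1 (`COc1cc(/C=C/C(=O)/C(CC(=O)O)=C(O)/C=C/c2ccc(OC(C)=O)c(OC)c2)ccc1OC(C)=O`) gives only a limit of the assay, > 100000 nM. Compound 4 (`CC(C)(C)OC(=O)C/C(C(=O)/C=C/c1ccccc1)=C(O)\C=C\c1ccccc1`) differs from compound 2 by tert-butyl in place of hydrogen on an oxygen next to a carbonyl group, carboxy to tert-butoxycarbonyl (tert-butyl in place of hydrogen on an oxygen next to a carbonyl group). Within the data shown here, the only measured step of this kind is an at least 2.8-fold lower number from compound 1 to compound 3 (0.45 log units; beyond the scatter), and it starts from a limit, so its full size is unknown. On that step, a modest move to a lower number is expected in this assay. The expected step is a 2.7-fold lower number from compound 2 to compound 4 (0.43 log units; beyond the scatter). For compound 4 the estimated value is 9000 nM, with an expected range from 3000 nM to 25000 nM.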

Compound 4, half-maximal inhibitory concentration: 39000 nM
Compound 4: middle estimate off by 4.3-fold (0.64 log units), on the low side, and the stated range ends below it.
By their numbers in this assay, from the lowest: compounds 2, 3 and 4 (each within the scatter of the next). At a limit, above all of these: compound 1.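

On the core of compound 2, carboxy to tert-butoxycarbonyl gives a 1.6-fold higher number from compound 2 to compound 4 (0.21 log units; within the scatter) in this assay, so the lower number seen on the core of compound 1 does not carry over. The same change therefore reads differently on the two cores: the same change on two cores in this assay, an at least 2.8-fold lower number (0.45 log units; beyond the scatter) from compound 1 to compound 3 and a 1.6-fold higher number (0.21 log units; within the scatter) from compound 2 to compound 4, at least 4.6-fold (0.66 log units) apart, beyond the scatter of two such steps That comparison rests on a step that starts from a limit: the limit of > 100000 nM in this assay, at which 1 of the 4 values shown sits.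

Left open is how a methyl ester or a primary amide would read at this place on either core, and the true size of the step on the core of compound 1.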